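The source may report more compounds than this note shows. Statements on the series, on what has been measured and on what is new or still open speak of the compounds shown alone.

Compound 3 `CC(C)n1cnc2c(NCc3ccc(C(=O)Nc4ccccc4N)cc3)nc(Cl)nc21` stands second of the three measured compounds in a functional assay on HepG2 cells (Homo sapiens) for antiproliferative activity, read by CCK-8 assay, with a stated time of 72 h, tested at 8 uM (a higher number here means a stronger effect of the compound at the concentration tested, a lower number a weaker effect), where compound 3 gives 74.4%. Compound 2 `Nc1ccccc1NC(=O)c1ccc(Cn2cnc3c(Nc4ccccc4)nc(Cl)nc32)cc1` gives 74.8%, a number within the scatter of compound 3, so the two cannot be ordered. Among the compounds with values here, compound 1 `COC(CCn1cnc2c(NCc3ccc(C(=O)Nc4ccccc4N)cc3)nc(Cl)nc21)OC` gives 34.2%, and the step of a number 40.2 percentage points higher from compound 1 to compound 3 (beyond the scatter) is the only one among the measured compounds that touches the group on the aromatic nitrogen.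

Compound 4 `CCCn1cnc2c(NCc3ccc(C(=O)Nc4ccccc4N)cc3)nc(Cl)nc21` differs from compound 3 in that one place: propyl in place of isopropyl on an aromatic nitrogen. Within the data shown here, the single step that bears on this change, from compound 1 to compound 3, was large, but it exchanged a longer chain carrying two oxygens for a three-carbon group. Among the measured compounds shown here, the change to compound 4 keeps the same atoms and only joins them differently, so there is no measured step that speaks for a shift of that size. Compound 4 is therefore expected to stay near compound 3 in this assay, with a step of a number 8.4 percentage points lower from compound 3 to compound 4 (within the scatter) that is estimated to fall within the scatter or only slightly below it. Compound 4 is estimated to give 66%, with a range from 46% to 84%.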

Compound 4, a percentage reported as inhibition, at one concentration (the size of the read-out at that concentration, not a potency): 14.1%
The estimate for compound 4 lay 51.9 percentage points above the measured number; measured number below the stated range.
By their numbers in this assay, from the lowest: compound 4; then compound 1; then compounds 3 and 2 (each within the scatter of the next).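

In this assay this position on the aromatic nitrogen proves sensitive to how its three carbons are joined, not only to what the chain carries: propyl in place of isopropyl gives a number 60.3 percentage points lower from compound 3 to compound 4 (beyond the scatter) with no change in atoms. Methyl in place of dimethoxymethyl gives a number 20.1 percentage points lower from compound 1 to compound 4 (beyond the scatter). This change does not restore the number. Among the compounds that differ only at this nitrogen, isopropyl in compound 3 stands well above the unbranched chains of compound 1 and compound 4, but no measurement shown here gives a reason for that gap.

The compounds shown leave open whether another branched or compact group, such as tert-butyl or cyclopropyl, would keep the number of compound 3, and whether ethyl or methyl would fall with propyl or rise towards isopropyl. They also leave open how a longer chain such as butyl, or a chain ending in an amine or a carboxylic acid, would behave at this nitrogen.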